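Swapping phenoxy for a pyridinyl amine: a solubility outlook

A few compounds are considered here, and "the series" means these few. Any claim that something is new, unique, unknown or untested is made for them only; others in the source may bear on it.

Measured compounds:
Compound 1 `Cn1cc(-c2cnc(NCc3c(F)ccc4c3CCO4)c3cn[nH]c(=O)c23)cn1`: 1000 nM
Compound 2 `Fc1ccc2c(c1CNc1ncc(Oc3ccccc3)c3nncn13)CCO2`: 8000 nM

Of the compounds shown here, two have been measured in a physicochemical assay for solubility, read by LC-MS, in phosphate buffer, with a stated time of 24 h, at pH 7.4; a lower number here means a less soluble compound, a higher number a more soluble compound. Compound 1 gives 1000 nM. Compound 2 gives 8000 nM, the higher of the two numbers. The gap between compound 2 and compound 1 lies beyond the scatter of the method, and compound 2 is the more soluble of the pair on these figures.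

Compound 3 `CN(c1cccnc1)c1cnc(NCc2c(F)ccc3c2CCO3)n2cnnc12` is the next step, and it keeps the core of compound 2 while changing a single group: methyl(pyridin-3-yl)amino in place of phenoxy on an aromatic carbon. Among the compounds with values here, no measured pair in this set shows the effect of such a change, so the expectation rests on the two numbers alone and on the change itself, as counted above.

In this assay compound 3 is expected to come out somewhat higher than compound 2, with a step of a 2.5-fold higher number from compound 2 to compound 3 (0.40 log units; beyond the scatter), modest in size but beyond the scatter. The estimate for compound 3 is 20000 nM, within a range from 5000 nM to 80000 nM.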

Compound 3, solubility: 47000 nM
The estimate for compound 3 lay 2.4-fold (0.37 log units) below the measured number, and the stated range covers the measured number.
By their numbers in this assay, from the lowest: compound 1; then compound 2; then compound 3.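

In this assay, within the data shown here, putting methyl(pyridin-3-yl)amino in place of phenoxy on this aromatic carbon gives a 5.9-fold higher number from compound 2 to compound 3 (0.77 log units; beyond the scatter) and is the first change in one place in this set, so it shows that the group at this position can move the number beyond the scatter. The swap alters more than one feature at once: the oxygen that links the ring to the core gives way to a nitrogen carrying a methyl, and the six-membered aromatic ring of carbon only gives way to a six-membered aromatic ring with 1 hetero atom, so this single step cannot divide the rise between those features. No measurement at hand explains the rise.

On these data alone, whether the rise follows the new ring or the new link stays open, and a pyridin-3-yloxy group or a methyl(phenyl)amino group on the same carbon would pull the two apart. Also open, as far as these compounds go, is how a saturated amine such as morpholine would read at this position, with no aromatic ring in the group at all.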